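A few compounds are considered here, and "the series" means these few. Any claim that something is new, unique, unknown or untested is made for them only; others in the source may bear on it.

The account concerns a small set of piperidine sulfonamide amides examined in a functional assay on CHO cells for positive allosteric modulation of muscarinic acetylcholine receptor M5 (Homo sapiens), read by calcium flux; a lower number here means a smaller maximal response, a higher number a larger maximal response. Compound 1, `CCN(Cc1ccccc1)C(=O)C1CCN(S(=O)(=O)c2ccc3occc3c2)CC1`, carries the 1-benzofuran-5-yl group on its sulfonyl sulfur, and in this assay compound 1 reaches 80%. Compound 2, `CCN(C(=O)C1CCN(S(=O)(=O)c2ccc(OC)cc2)CC1)[C@@H](C)c1ccccc1`, and compound 3, `CCN(C(=O)C1CCN(S(=O)(=O)c2ccc(OC)cc2)CC1)[C@H](C)c1ccccc1`, both carry 4-methoxyphenyl there and differ from each other only in the configuration as drawn (the fact that compounds 2 and 3 differ only in the configuration as drawn). For compound 2 the result in this assay is "not determined" (no result reported), so no number is available for it. Compound 3 gives 90% in this assay, which is the larger of the two numbers recorded, although the difference from compound 1 lies within the scatter of repeated measurements, so no ordering of the two can be claimed.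

The next compound, compound 4, `CCN(C(=O)C1CCN(S(=O)(=O)c2ccc3occc3c2)CC1)[C@H](C)c1ccccc1`, keeps the amide side of compound 3 unchanged and carries 1-benzofuran-5-yl in place of 4-methoxyphenyl on a sulfonyl sulfur instead.

Because compound 1 gives 80% and compound 3 gives 90% in this assay, two values that lie within the scatter of each other, the step from the methoxyphenyl to the benzofuranyl group is expected to produce no change beyond the scatter, and the move a number 5 percentage points lower from compound 3 to compound 4 (within the scatter) is estimated to be small. Compound 4 is therefore expected to reach about 85% in this assay, with a plausible range from 65% to 100%.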

Compound 4, largest response reached (reported as percent of maximum), in percent of the reference or control that the assay uses: 80%
Compound 4: middle estimate off by 5 percentage points, on the high side; low and high end bracket the measured number.
By their numbers in this assay, from the lowest: compounds 1, 4 and 3 (each within the scatter of the next).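

In this assay, the exchange of 4-methoxyphenyl for 1-benzofuran-5-yl on a sulfonyl sulfur can now be read on a pair differing in that one place, and it gives a number 10 percentage points lower from compound 3 to compound 4 (within the scatter) as its step, so the largest response reached does not tell these two groups apart at this position. A second single-place pair now exists on the amide side, where methyl in place of hydrogen on a saturated chain carbon bound to an amide-type nitrogen and an aromatic carbon gives no change at the digits printed from compound 1 to compound 4 (within the scatter) with 1-benzofuran-5-yl held constant, so neither exchange shifts the response beyond the scatter. Nothing available here offers a reason for either step.

On these data alone, whether the response holds with something other than these two aromatic groups on the sulfonyl sulfur, such as a simple alkyl chain or a phenyl ring bearing an amine or a carboxylic acid, stays open, as does the effect of a longer chain in place of the added methyl. As far as these compounds go, what the configuration as drawn contributes to the response also stays open: the fact that compounds 2 and 3 differ only in the configuration as drawn.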